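The compounds below may be only part of what the source reports. "The series", "measured", "known", "first", "only" and "open" are said of these compounds alone.

Measured so far in a functional assay on A549 cells (Homo sapiens) for inhibition, read by CCK-8 assay, with a stated time of 48 h; a lower number here means a stronger inhibitor, a higher number a weaker inhibitor:
compound 1 `COc1cc(-c2ccnc3cc(-c4ccc5cc[nH]c5c4)nn23)cc(OC)c1OC` gives 170 nM
compound 2 `COc1cc(-c2ccnc3cc(-c4ccc(C(C)=O)cc4)nn23)cc(OC)c1OC` gives 4100 nM
compound 3 `COc1ccc(-c2cc3nccc(-c4cc(OC)c(OC)c(OC)c4)n3n2)cc1` gives 376 nM

Compound 1 holds the lowest number of the three in this assay. Its nearest neighbour is compound 3, reached by a 2.2-fold higher number from compound 1 to compound 3 (0.34 log units; beyond the scatter), a modest step. Its furthest is compound 2, reached by a 24-fold higher number from compound 1 to compound 2 (1.38 log units; beyond the scatter), a large step. Between the two phenyl analogues the step is an 11-fold lower number from compound 2 to compound 3 (1.04 log units; beyond the scatter), again large.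

Compound 4 `COc1cc(-c2ccnc3cc(-c4ccc(F)cc4)nn23)cc(OC)c1OC` is the unmeasured member. It differs from compound 1 in one place: 4-fluorophenyl in place of 1H-indol-6-yl on an aromatic carbon. Both measured steps from compound 1 bear on this, since each swaps the same 1H-indol-6-yl for a substituted phenyl at the same aromatic carbon. Both go the same way, higher, the 4-methoxyphenyl modestly and the 4-acetylphenyl strongly. Among the compounds with values here, no measured compound carries a 4-fluorophenyl, so the position of compound 4 between those two outcomes is not fixed by the data. A step upward beyond the scatter is expected, closer to the modest end seen with compound 3 than to the large end seen with compound 2.

Compound 4 is therefore estimated at 600 nM in this assay, within 200 nM to 2000 nM. That estimate corresponds to an expected step of a 3.5-fold higher number from compound 1 to compound 4 (0.55 log units; beyond the scatter).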

Compound 4, half-maximal inhibitory concentration: 3800 nM
The estimate for compound 4 lay 6.3-fold (0.80 log units) below the measured number; the measured number lies above the stated range.
By their numbers in this assay, from the lowest: compound 1; then compound 3; then compounds 4 and 2 (each within the scatter of the next).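

In this assay, 4-fluorophenyl at this aromatic carbon of the shared core falls far short of the 1H-indol-6-yl of compound 1, with a 22-fold higher number from compound 1 to compound 4 (1.35 log units; beyond the scatter), so a small substituent on the phenyl ring does not preserve the number. Within the data shown here, the large rise seen with 4-acetylphenyl is therefore not peculiar to the acetyl group: fluoro and acetyl cannot be separated, with a 1.1-fold lower number from compound 2 to compound 4 (0.03 log units; within the scatter), while the change away from methoxy gives a 10-fold higher number from compound 3 to compound 4 (1.00 log units; beyond the scatter), making compound 3 the one phenyl analogue that stays near compound 1. Nothing available explains why methoxy parts from fluoro and acetyl at this place.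

Still open, as far as these compounds go, is whether the methoxy result depends on the oxygen attached to the phenyl ring or extends to groups such as hydroxy, ethoxy, amino or dimethylamino in the same place on that ring. Also open, from the compounds shown here alone, is whether the lead of the 1H-indol-6-yl over the phenyl analogues depends on its ring hydrogen, which a 1-methylindol-6-yl group would test, or on the fused ring itself, which a benzofuran-6-yl group would test.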